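The source may report more compounds than this note shows. Statements on the series, on what has been measured and on what is new or still open speak of the compounds shown alone.

Compound 1 `Cc1cccc(NC(=O)CN2CCN(c3ccc(Cl)cn3)CC2)c1` was tested in a functional assay on cells for agonist activity at D(4) dopamine receptor (Homo sapiens), read by TR-FRET and cAMP accumulation, with a stated time of 30 min (a higher number here means that more compound is needed for the effect, a lower number that less compound is needed), and reported as "not active" (no number reported), so no number fixes where it stands. Compound 2 `Cc1cccc(NC(=O)CN2CCC(c3ccccc3)CC2)c1`, tested in the same way, gives 15.4 nM in this assay. Compound 3 `O=C(CN1CCN(c2ccc(Cl)cn2)CC1)Nc1cccnc1` keeps the core of compound 1 and differs from it only by pyridin-3-yl in place of 3-methylphenyl on an amide-type nitrogen. Among the compounds with values here, no measured step exists for this change, and with compound 1 giving "not active" (no number reported) no gain beyond the scatter is expected from it. Compound 3 is therefore estimated at 6000 nM, within 1000 nM to 30000 nM, with a real chance that again no number is obtained.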

Compound 3, half-maximal effective concentration: "not active" (no number reported)
Compound 3: no number reported; there is nothing to compare the estimate with.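

Compound 1 and compound 3 both lack a number, so no step can be read for 3-methylphenyl to pyridin-3-yl. Going by these compounds, whether this change alters activity in a compound with a measurable value, such as compound 2, stays open. No evidence bears on this result.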